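The compounds below may be only part of what the source reports. "The series", "measured", "known", "first", "only" and "open" are said of these compounds alone.

Compound 1 `O=C1C=C(NC2CCCC2)C(=O)c2c1nc1n2[C@H]2OC[C@@H](O)[C@H]2OC1` carries a cyclopentylamino group on its shared core. In a functional assay on ECa-109 cells for inhibition, with ECa-109 cell line (Homo sapiens) as the target, read by sulforhodamine B assay (a higher number here means a weaker inhibitor, a lower number a stronger inhibitor), compound 1 gives > 16000 nM, which is a limit of the assay rather than a number. Two measured relatives replace the cyclopentyl group with an aromatic ring on the amine nitrogen: compound 2 `CCOc1ccc(NC2=CC(=O)c3nc4n(c3C2=O)[C@H]2OC[C@@H](O)[C@H]2OC4)cc1` gives 3210 nM in this assay, and compound 3 `O=C1C=C(Nc2ccc(C(F)(F)F)cc2)C(=O)c2c1nc1n2[C@H]2OC[C@@H](O)[C@H]2OC1` gives 5500 nM. Those changes gave an at least 4.9-fold lower number from compound 1 to compound 2 (0.69 log units; beyond the scatter) and an at least 2.9-fold lower number from compound 1 to compound 3 (0.46 log units; beyond the scatter), while between the two aromatic groups there was a 1.7-fold higher number from compound 2 to compound 3 (0.23 log units; within the scatter).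

Compound 4 `O=C1C=C(N2CCCCC2)C(=O)c2c1nc1n2[C@H]2OC[C@@H](O)[C@H]2OC1` differs from compound 1 in another way: piperidin-1-yl in place of cyclopentylamino on a double-bonded ring carbon. For the measured compounds named here, no measured step rearranges the ring in this fashion, so the two aromatic replacements offer no direct guide; they show only that moving away from cyclopentylamino can lower the number. Because compound 1 sits at the limit of > 16000 nM in this assay, at which 1 of the 3 values shown sits, any expected step is uncertain. Compound 4 is expected to show a step that the limit leaves unreadable from compound 1 to compound 4, a change not beyond the scatter. Compound 4 is therefore estimated at 20000 nM, within a range from 6000 nM to 60000 nM.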

Compound 4, half-maximal inhibitory concentration: > 8000 nM
Compound 4: a limit, no number; the forecaster's own chance of this, stated with the estimate: 65%; the middle value is on the limit's open side.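

For the compounds shown here, compound 1 and compound 4 each give only a limit of the assay in this assay, not a number, so no step between them can be read. The compounds shown leave open whether piperidin-1-yl or cyclopentylamino on the shared core gives the stronger inhibitor.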